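The source may hold more compounds than are shown below. What is called first, only, known or untested is meant among the compounds shown, and "the series" means these compounds.

Working notes on the series. Compound 2 `COc1ccc(Cn2cc(CNC(=O)c3ccc([N+](=O)[O-])o3)nn2)cc1` and compound 1 `O=C(NCc1cn(Cc2ccc([N+](=O)[O-])cc2)nn1)c1ccc([N+](=O)[O-])o1` share one core and differ only in the group on the benzyl ring. In an ADME assay on MRC5 cells (Homo sapiens) for cytotoxicity (on this read-out higher numbers stand for weaker inhibition and lower numbers for stronger inhibition), compound 2 gives 146000 nM, while compound 1 gives 213000 nM; the step of a 1.5-fold lower number from compound 1 to compound 2 (0.16 log units; within the scatter) is the only one measured so far, and it lies within the scatter. Compound 2 therefore stands at the lower of the two numbers, but with nothing to separate it from compound 1.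

Compound 3 `O=C(NCc1cn(Cc2ccc(F)c(Cl)c2)nn1)c1ccc([N+](=O)[O-])o1` keeps the core and brings the change (3-chloro-4-fluorophenyl in place of 4-methoxyphenyl on a saturated chain carbon bound to an aromatic nitrogen). For the measured compounds named here, the one measured step, a 1.5-fold lower number from compound 1 to compound 2 (0.16 log units; within the scatter), bears on it only in that it too alters the group on the benzyl ring, and that step stayed within the scatter. Going by the values given here, no measured step concerns halogens on this ring, so the expectation rests on that single comparison. The step of a 1.0-fold higher number from compound 2 to compound 3 (0.01 log units; within the scatter) is expected to stay within the scatter, in no set direction. For compound 3 in this assay the estimate is 150000 nM, with a range from 70000 nM to 320000 nM.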

Compound 3, half-maximal inhibitory concentration: 254000 nM
For compound 3 the middle estimate is 1.7-fold (0.23 log units) below the measured one; the range from low to high includes it.
By their numbers in this assay, from the lowest: compounds 2, 1 and 3 (each within the scatter of the next).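

In this assay, at this place on a saturated chain carbon bound to an aromatic nitrogen, 3-chloro-4-fluorophenyl gives a 1.7-fold higher number from compound 2 to compound 3 (0.24 log units; within the scatter) and, set against the 4-nitrophenyl group, a 1.2-fold higher number from compound 1 to compound 3 (0.08 log units; within the scatter); both steps lie within the scatter. The earlier pair compared only two groups with a single substituent on the phenyl ring, whereas this result adds a group carrying two halogens, and it still does not separate from either of them, so the three compounds cannot be told apart on this read-out and no order among these groups can be claimed. Nothing available explains this result.

As far as these compounds go, whether an amine or a carboxylic acid on the phenyl ring, or a longer chain at this same place, would move the number beyond the scatter remains open. For the compounds shown here, all three compounds also keep the shared core unchanged and vary only this one group, so they say nothing about how a change elsewhere in the core would read in this assay.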